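This account rests on a few compounds, and the source may have more. Where it says the series, first, only, none or still open, it means among the compounds named here.

Compounds measured so far in an ADME assay on LLC-MK2 cells (Macaca mulatta) for cytotoxicity, read by spectrophotometry and crystal violet staining, with a stated time of 4 days; on this read-out higher numbers stand for lower toxicity in this test and lower numbers for higher toxicity in this test:
- compound 1 `CC(C)n1ncc2c(C(=O)Nc3ccccc3F)cc(-c3cccnc3)nc21`: 50000 nM
- compound 2 `CC(C)n1ccc2c(C(=O)Nc3ccc(F)cc3)cc(-c3cccs3)nc21`: > 200000 nM (a limit)
- compound 3 `CC(C)n1ncc2c(C(=O)Nc3cccc(F)c3F)cc(-c3cccs3)nc21`: 75000 nM

Of the two numbers that this assay has yielded, compound 3 holds the higher one. Its nearest neighbour is compound 1, whose value lies within the scatter of repeated measurements, so the two compounds cannot be told apart on this read-out. For compound 2 the assay reported no number, only a limit (the limit of > 200000 nM in this assay, at which 1 of the 3 values shown sits).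

The next compound, compound 4 `CC(C)n1ncc2c(C(=O)Nc3ccccn3)cc(-c3cccs3)nc21`, is derived from compound 3 by one change on the amide-type nitrogen:

pyridin-2-yl in place of 2,3-difluorophenyl on an amide-type nitrogen

Among the measured compounds shown here, no step between two measured compounds is available, and none of the measured pairs differs in one place, so there is no direct precedent for this exchange. Given that the two numbers seen so far sit within the scatter of each other and the third value is a limit, the step from compound 3 to compound 4 in this assay is expected to be small, with no direction clearly favoured; the estimate is a 1.2-fold higher number from compound 3 to compound 4 (0.08 log units; within the scatter). Compound 4 is accordingly expected to give about 90000 nM, in a range from 35000 nM to 230000 nM, with a real chance that the assay returns only a limit.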

Compound 4, half-maximal cytotoxic concentration: > 200000 nM
Compound 4 gave a limit, no number (the forecaster's own chance of this, stated with the estimate: 30%); middle value at least 2.2-fold (0.34 log units) from the limit.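

In this assay, among the compounds shown here, putting pyridin-2-yl in place of 2,3-difluorophenyl on the amide-type nitrogen gives the first step that can be read between two compounds differing in one place: an at least 2.6-fold higher number from compound 3 to compound 4 (0.42 log units; beyond the scatter). For the compounds shown here, this shows that, with the rest of compound 3 held fixed, the group on this nitrogen can shift the read-out beyond the scatter, here towards lower toxicity in this test, which the earlier compounds could not show because no two of them differed in one place alone. From the compounds shown here alone, the step has only a lower bound and its full size remains unknown, because compound 4 returned a limit rather than a number: the limit of > 200000 nM in this assay, at which 2 of the 4 values shown sit.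

The compounds shown do not separate the entry of the ring nitrogen of pyridin-2-yl from the departure of the fluorine atoms of 2,3-difluorophenyl as the source of this step. They also leave open how a plain phenyl, a pyridin-3-yl or a cyclohexyl group on the same nitrogen would read in this assay.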